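Swapping the amide substituent on a thiophene-bearing core

The source may report more compounds than this note shows. Statements on the series, on what has been measured and on what is new or still open speak of the compounds shown alone.

Four compounds share a fused heteroaromatic core that carries an amino group, a trifluoromethyl group and an amide. Compound 1 `Nc1c(C(=O)NC2CCCC2)oc2nc(-c3ccccc3)cc(C(F)(F)F)c12` has a cyclopentyl group on the amide nitrogen and a phenyl group on the core. In a functional assay on HepG2 cells (Homo sapiens) for antiproliferative activity, read by MTT assay (a lower number here means a stronger inhibitor, a higher number a weaker inhibitor), compound 1 gives 32400 nM. Compound 2 `Cc1ccc(/C=N/NC(=O)c2oc3nc(-c4ccccc4)cc(C(F)(F)F)c3c2N)cc1` keeps the phenyl-bearing core but replaces the cyclopentyl group with a larger group: a group of 9 heavy atoms (8 carbon, 1 nitrogen; one six-membered aromatic ring of carbon only) in place of a group of 5 heavy atoms (5 carbon; one five-membered non-aromatic ring of carbon only), on an amide-type nitrogen. In this assay compound 2 gives 8900 nM, so the exchange gives a 3.6-fold lower number from compound 1 to compound 2 (0.56 log units; beyond the scatter).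

Compound 3 `Nc1c(C(=O)NC2CCCC2)oc2nc(-c3cccs3)cc(C(F)(F)F)c12` keeps the cyclopentyl amide of compound 1 but its core differs: thiophen-2-yl in place of phenyl on an aromatic carbon. In this assay compound 3 gives 20800 nM, and the change in the core gives a 1.6-fold lower number from compound 1 to compound 3 (0.19 log units; within the scatter), which does not separate the two compounds.

Compound 4 `Cc1ccc(/C=N/NC(=O)c2oc3nc(-c4cccs4)cc(C(F)(F)F)c3c2N)cc1` has not yet been measured. It differs from compound 3 in the same way that compound 2 differs from compound 1: a group of 9 heavy atoms (8 carbon, 1 nitrogen; one six-membered aromatic ring of carbon only) in place of a group of 5 heavy atoms (5 carbon; one five-membered non-aromatic ring of carbon only), on an amide-type nitrogen. The place of the change is described in the same words in both pairs, so it is the same change made on a core that differs only in the thiophen-2-yl group. Because the step of a 3.6-fold lower number from compound 1 to compound 2 (0.56 log units; beyond the scatter) was clear, the step from compound 3 to compound 4 is expected to be of a similar size, a 3.5-fold lower number from compound 3 to compound 4 (0.54 log units; beyond the scatter). This rests on a single earlier example, so the range is kept wide. Compound 4 is therefore estimated at 6000 nM in this assay, with a likely span from 2500 nM to 14000 nM.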

Compound 4, half-maximal inhibitory concentration: 19800 nM
Compound 4: middle estimate off by 3.3-fold (0.52 log units), on the low side; measured number outside the range, above it.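

On the core with the thiophen-2-yl group, the same amide change gives a 1.1-fold lower number from compound 3 to compound 4 (0.02 log units; within the scatter) in this assay, so the clear step seen on the phenyl-bearing core does not carry over to this second core: the same change on two cores in this assay, a 3.6-fold lower number (0.56 log units; beyond the scatter) from compound 1 to compound 2 and a 1.1-fold lower number (0.02 log units; within the scatter) from compound 3 to compound 4, 3.5-fold (0.54 log units) apart, beyond the scatter of two such steps Seen from the other side, exchanging phenyl for thiophen-2-yl gives a 2.2-fold higher number from compound 2 to compound 4 (0.35 log units; beyond the scatter) when the larger group sits on the amide nitrogen, and this step does not match the one seen with the cyclopentyl amide: the same change on two cores in this assay, a 1.6-fold lower number (0.19 log units; within the scatter) from compound 1 to compound 3 and a 2.2-fold higher number (0.35 log units; beyond the scatter) from compound 2 to compound 4, 3.5-fold (0.54 log units) apart, beyond the scatter of two such steps These four compounds show that, here, the two changes do not simply add up, but they do not show why, and with only one such set they cannot tell which of the two cores is the more typical guide for other compounds in the series.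

From the compounds shown here alone, it remains open how the amide change would behave on a core carrying another group in place of phenyl or thiophen-2-yl, such as furan-2-yl or pyridin-3-yl. Going by these compounds, it is equally open whether a different group on the amide nitrogen, such as cyclohexyl or benzyl, would show the same dependence on the core.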